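Chromanol acetamides: cytotoxicity on neuroblastoma cells

A few compounds are considered here, and "the series" means these few. Any claim that something is new, unique, unknown or untested is made for them only; others in the source may bear on it.

Measured so far:
compound 1, `COc1cc2c(cc1O)CCC(C)(CC(=O)O)O2`, 61%
compound 2, `COc1cc2c(cc1O)CCC(C)(CCNC(=O)C[C@H]1OC(O)[C@H](O)[C@@H](O)[C@@H]1O)O2`, 86.6%

In an ADME assay on SH-SY5Y cells (Homo sapiens) for cytotoxicity, read by MTT assay, with a stated time of 24 h, tested at 50 uM (a lower number here means a stronger effect, a higher number a weaker effect of the compound at the concentration tested), compound 1 gives 61% and compound 2 gives 86.6%. Going by the values given here, compound 2 stands highest of the two numbers; its only neighbour is compound 1, whose value lies lower by a gap beyond the scatter. Among the compounds with values here, no single-point step between measured compounds is available, so nothing about the effect of any one change has been measured directly.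

Compound 3, `COc1cc2c(cc1O)CCC(C)(CCNC(C)=O)O2`, keeps the core of compound 2 and differs from it only at the chain: hydrogen in place of 3,4,5,6-tetrahydroxyoxan-2-yl on a saturated chain carbon bound to a carbonyl carbon. Within the data shown here, with no measured step to rest on, the direction of this change in this assay is uncertain; the expectation is for a modest move downward from compound 2, near the edge of the scatter rather than clearly beyond it, since compound 1, which also lacks the sugar, gives 61%. For compound 3 the expected step is a number 11.6 percentage points lower from compound 2 to compound 3 (beyond the scatter). Compound 3 is estimated at 75%, with a range from 55% to 95%.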

Compound 3, a percentage reported as activity, at one concentration (the size of the read-out at that concentration, not a potency): 66.5%
For compound 3 the middle estimate is 8.5 percentage points above the measured one, and the stated range covers the measured number.
By their numbers in this assay, from the lowest: compounds 1 and 3 (each within the scatter of the next); then compound 2.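

Hydrogen in place of 3,4,5,6-tetrahydroxyoxan-2-yl on a saturated chain carbon bound to a carbonyl carbon gives a number 20.1 percentage points lower from compound 2 to compound 3 (beyond the scatter) in this assay, the first direct measure of this change, and it ties the higher number of compound 2 to that group within this pair. In this assay, acetamidomethyl in place of carboxy on a saturated chain carbon bound to a saturated ring carbon gives a number 5.5 percentage points higher from compound 1 to compound 3 (within the scatter), so this exchange does not separate the two compounds. No measurement at hand bears on the reason for either step.

Going by these compounds, whether the step needs the whole 3,4,5,6-tetrahydroxyoxan-2-yl group remains open, as a plain oxan-2-yl ring or a single hydroxyl at the same place would test. A longer chain or an amine at this place also remains unplaced in this series.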